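The compounds below may be only part of what the source reports. "The series", "measured", "known", "first", "only" and "open" are said of these compounds alone.

Compound 1 `O=C1CC(c2ccc(NC(=O)c3ccc(Cl)c(C(F)(F)F)c3)cc2)=Nc2cnn(Cc3ccccc3)c2N1`: 13100 nM
Compound 2 `Cc1cn(-c2cc(NC(=O)Nc3ccc(C4=Nc5cnn(Cc6ccccc6)c5NC(=O)C4)cc3)cc(C(F)(F)F)c2)cn1`: > 30000 nM
Compound 3 `COc1ccc(Cn2ncc3c2NC(=O)CC(c2cccc(NC(=O)Nc4cccc(Cl)c4)c2)=N3)cc1`: 910 nM

All three were read in a functional assay on A375P cells (Homo sapiens) for inhibition, read by MTT assay, with a stated time of 24 h; on this read-out lower numbers stand for stronger inhibition of growth and higher numbers for weaker inhibition of growth. The entry for compound 2 is a limit of the assay, not a number. Compound 3 has the lowest of the two numbers, and compound 1 sits higher, beyond the scatter.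

Compound 4 `COc1ccc(Cn2ncc3c2NC(=O)CC(c2cccc(NC(=O)Nc4ccc(Cl)cc4)c2)=N3)cc1` carries 4-chlorophenyl in place of 3-chlorophenyl on an amide-type nitrogen. Among the measured compounds shown here, no measured pair shows a change of this kind, so the expectation starts from compound 3 at 910 nM. No step beyond the scatter is expected in this assay. The estimated change is small: a 1.3-fold higher number from compound 3 to compound 4 (0.12 log units; within the scatter). For compound 4 the expected value is 1200 nM, with an estimated range of 400 nM to 4000 nM.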

Compound 4, concentration for 50% growth inhibition: 640 nM
Compound 4: middle estimate off by 1.9-fold (0.27 log units), on the high side; the range from low to high includes it.
By their numbers in this assay, from the lowest: compounds 4 and 3 (each within the scatter of the next); then compound 1. At a limit, above all of these: compound 2.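

In this assay, among the compounds shown here, the earlier compounds offered no pair differing in one place; this first pair gives a 1.4-fold lower number from compound 3 to compound 4 (0.15 log units; within the scatter). On the amide-type nitrogen, 4-chlorophenyl and 3-chlorophenyl therefore cannot be told apart, so the site of the chlorine on this phenyl ring makes no readable difference in this one pair. No available measurement bears on a cause for this step.

On these data alone, how a phenyl carrying an amine or a carboxylic acid in place of the chlorine would read on this nitrogen remains open. As far as these compounds go, whether the same exchange gives a similar step with other groups elsewhere on the shared core also remains open.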